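The compounds below may be only part of what the source reports. "The series", "measured", "known", "first", "only" and "open" are said of these compounds alone.

Measured compounds:
Compound 1 `Cc1cc(S(=O)(=O)Nc2nc3cscc3c(=O)n2N)c(S)cc1Cl`: 17700 nM
Compound 2 `Cc1cc(S(=O)(=O)Nc2nc3cc(-c4ccccc4)sc3c(=O)n2Cc2ccccc2)c(S)cc1Cl`: > 100000 nM (a limit of the assay)

In a functional assay on SF-268 cells (Homo sapiens) for inhibition (on this read-out higher numbers stand for weaker inhibition of growth and lower numbers for stronger inhibition of growth), compound 1 gives 17700 nM. In this assay compound 2 gives > 100000 nM, which is a limit of the assay and not a number. Within the data shown here, the two compounds differ in more than one place, so their values show only that compound 1 carries a number while compound 2 sits at the limit, as the evidence states: the limit of > 100000 nM in this assay, at which 1 of the 2 values shown sits.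

Compound 3 `Cc1cc(S(=O)(=O)Nc2nc3cc(-c4ccc(Cl)cc4)sc3c(=O)n2Cc2ccccc2)c(S)cc1Cl` is not yet measured. It differs from compound 2 by chloro in place of hydrogen on an aromatic carbon. Among the measured compounds shown here, no measured step of this kind is on hand. The step of a number no higher from compound 2 to compound 3 (the limit leaves the size open) is expected to be none beyond the usual scatter, with no direction to assign, because compound 2 stands at the limit of > 100000 nM in this assay, at which 1 of the 2 values shown sits, and nothing here suggests the chloro moves the value away from it. Compound 3 is therefore expected at 100000 nM, within 30000 nM to 300000 nM, most likely reported again as a limit.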

Compound 3, concentration for 50% growth inhibition: > 100000 nM
Compound 3 ended at the assay's limit (the forecaster's own chance of this, stated with the estimate: 75%); the middle value sits exactly at the limit.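

In this assay compound 3 gives > 100000 nM, a limit of the assay and not a number. Among these compounds, compound 2 also stands at a limit, and no step between compound 2 and compound 3 can be read. Left open is whether phenyl to 4-chlorophenyl changes growth inhibition at all: the limit of > 100000 nM in this assay, at which 2 of the 3 values shown sit.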